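The compounds below may be only part of what the source reports. "The series", "measured", "known", "first", "only" and "open" are said of these compounds alone.

Compound 1 `COc1ccc(-c2nc(CNC(C)=O)sc2-c2ccc(OC)cc2)cc1` gives 8.1 uM
Compound 2 `COc1ccc(-c2nc(C(=O)N3CCNC(CCO)C3)sc2-c2ccc(OC)cc2)cc1` gives 9.5 uM
Compound 3 `COc1ccc(-c2nc(/C=C/C(=O)N3CCN(C)CC3)sc2-c2ccc(OC)cc2)cc1` gives 20 uM

In a functional assay (aorta) with Rattus norvegicus as the target (a lower number here means that less compound is needed, a higher number that more compound is needed for the effect), compound 1 stands at the lowest of the three numbers. Compound 2 lies within the usual scatter of compound 1, so the two cannot be told apart, while compound 3 stands beyond the scatter higher than compound 1. Compound 4 `COc1ccc(-c2nc(C3=CCN(C)CC3)sc2-c2ccc(OC)cc2)cc1` has not yet been measured. It differs from compound 1 in one place: a group of 7 heavy atoms (6 carbon, 1 nitrogen; one six-membered non-aromatic ring with 1 hetero atom) in place of a group of 5 heavy atoms (3 carbon, 1 nitrogen, 1 oxygen; no ring), on an aromatic carbon The three measured compounds carry varied groups on that aromatic carbon of the shared core and all fall in a narrow band, which gives no ground to expect a large move. The step of a 1.2-fold higher number from compound 1 to compound 4 (0.09 log units; within the scatter) is expected to be small, not clearly beyond the scatter, in either direction. Compound 4 is estimated at 10 uM, with a range from 3.5 uM to 30 uM.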

Compound 4, concentration for half-maximal effect: 5.9 uM
For compound 4 the middle estimate is 1.7-fold (0.23 log units) above the measured one, and the stated range covers the measured number.
By their numbers in this assay, from the lowest: compounds 4, 1 and 2 (each within the scatter of the next); then compound 3.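

In this assay, the change on this aromatic carbon gives a 1.4-fold lower number from compound 1 to compound 4 (0.14 log units; within the scatter), so the two compounds cannot be told apart. The position therefore accepts a six-membered non-aromatic ring with one hetero atom in place of the open acetamidomethyl chain, and the hydrogen-bond donor of that chain is not needed to keep the number in this range. Nothing measured here gives a reason for this result. The compounds shown leave open whether a carboxylic acid or a primary amine on this carbon would also hold the number, and whether a longer chain would.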